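Will a longer chain move compound 3?

A few compounds are considered here, and "the series" means these few. Any claim that something is new, unique, unknown or untested is made for them only; others in the source may bear on it.

In a functional assay, with a stated time of 10 min (on this read-out lower numbers stand for stronger inhibition and higher numbers for weaker inhibition), compound 1 `CCCCCCCCOc1cc(OC)c(Br)cc1C(C)=O` gives 38100000 nM and compound 2 `CCCCCCCCCCOc1cc(OC)c(Br)cc1C(C)=O` gives 29700000 nM while compound 3 `CCCCCCCCCCCCOc1cc(OC)c(Br)cc1C(C)=O` gives 23100000 nM and so sits within the scatter of both. Compound 4 `CCCCCCCCCCCCCCCCOc1cc(OC)c(Br)cc1C(C)=O` differs from compound 3 in one place: butyl in place of hydrogen on a saturated chain carbon, ten or more bonds along the chain from an oxygen on an aromatic ring and nothing else changes. The same butyl change elsewhere along the chain gave a 1.6-fold lower number from compound 1 to compound 3 (0.22 log units; within the scatter) and the smaller ethyl changes gave a 1.3-fold lower number from compound 1 to compound 2 (0.11 log units; within the scatter) and a 1.3-fold lower number from compound 2 to compound 3 (0.11 log units; within the scatter) with all three inside the scatter. No step beyond the scatter is therefore expected in this assay and the expected step is a 1.4-fold lower number from compound 3 to compound 4 (0.16 log units; within the scatter) for this change. For compound 4 the estimated value is 16000000 nM with an expected range of 8000000 nM to 32000000 nM.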

Compound 4, half-maximal inhibitory concentration: 100000 nM
Estimate against measurement, compound 4: 160-fold (2.20 log units) above; the whole stated range lies above it.
By their numbers in this assay, from the lowest: compound 4; then compounds 3, 2 and 1 (each within the scatter of the next).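

In this assay this chain position, which had seemed almost insensitive to added length, proves able to respond strongly. Butyl in place of hydrogen gives a 230-fold lower number from compound 3 to compound 4 (2.36 log units; beyond the scatter) and the longer hexyl and octyl changes give a 300-fold lower number from compound 2 to compound 4 (2.47 log units; beyond the scatter) and a 380-fold lower number from compound 1 to compound 4 (2.58 log units; beyond the scatter) along this series. The steps among compounds 1, 2 and 3 all lie within the scatter, so across these four compounds the change is abrupt rather than gradual and appears only at compound 4.

No evidence here accounts for so large a step. As far as these compounds go, whether a still longer chain, or a chain ending in an amine or a carboxylic acid, would keep the number this low remains open.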